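A few compounds are considered here, and "the series" means these few. Any claim that something is new, unique, unknown or untested is made for them only; others in the source may bear on it.

Measured so far in a functional assay on cells (Platelet, Homo sapiens) for inhibition; on this read-out lower numbers stand for stronger inhibition and higher numbers for weaker inhibition:
- compound 1 `CCOC(=O)c1ccc(-c2nn(Cc3ccccc3F)c3ccccc23)cc1`: 110 nM
- compound 2 `CCOC(=O)c1ccc(-c2nn(Cc3cccc(F)c3)c3ccccc23)cc1`: 270 nM
- compound 3 `CCOC(=O)c1ccc(-c2nn(Cc3ccc(OC)cc3)c3ccccc23)cc1`: 620 nM

Of the three, compound 3 has the highest number, 620 nM, and is therefore the weakest inhibitor in this assay. Compound 4 `CCOC(=O)c1ccc(-c2nn(Cc3ccncc3)c3ccccc23)cc1` is the next to be considered. Its difference from compound 3 is pyridin-4-yl in place of 4-methoxyphenyl on a saturated chain carbon bound to an aromatic nitrogen, with pyridin-4-yl in place of 4-methoxyphenyl on a saturated chain carbon bound to an aromatic nitrogen.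

The measured steps that bear on this change were all made at the same place: a 2.5-fold higher number from compound 1 to compound 2 (0.39 log units; beyond the scatter), a 2.3-fold higher number from compound 2 to compound 3 (0.36 log units; beyond the scatter) and a 5.6-fold higher number from compound 1 to compound 3 (0.75 log units; beyond the scatter). All three were modest, yet each carries a ring of carbon only, so none shows what a ring with a hetero atom does. A modest step is therefore expected in this assay, tentatively towards a higher number, though the direction is uncertain. The estimated step is a 1.5-fold higher number from compound 3 to compound 4 (0.16 log units; within the scatter). The expected value for compound 4 is 900 nM, within an estimated range of 250 nM to 3000 nM.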

Compound 4, half-maximal inhibitory concentration: 5630 nM
Estimate against measurement, compound 4: 6.3-fold (0.80 log units) below, and the stated range ends below it.
By their numbers in this assay, from the lowest: compound 1; then compound 2; then compound 3; then compound 4.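

On a saturated chain carbon bound to an aromatic nitrogen, pyridin-4-yl is the only ring with a hetero atom among these compounds, and in this assay it gives a 9.1-fold higher number from compound 3 to compound 4 (0.96 log units; beyond the scatter), a 21-fold higher number from compound 2 to compound 4 (1.32 log units; beyond the scatter) and a 51-fold higher number from compound 1 to compound 4 (1.71 log units; beyond the scatter). The last two of these steps are large, whereas every step among the rings of carbon only was modest, so compound 4 is the weakest inhibitor of the four and those modest steps did not foretell its place. No supporting measurement is available to explain this loss.

On these data alone, it remains open whether other rings with a hetero atom, such as thiophene or pyrimidine, would stand as far from compound 1 as compound 4 does. As far as these compounds go, the place of an unsubstituted phenyl ring in this order also remains open.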